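The compounds below may be only part of what the source reports. "The series", "measured", "known", "first", "only" and "open" are said of these compounds alone.

Compound 1 `Cc1nc(C(NC(=O)C(=O)Nc2ccc(F)c(F)c2)C2CCCCN2)sc1CO`: > 87000 nM
Compound 2 `Cc1nc(C(NC(=O)C(=O)Nc2ccc(F)cc2F)C2CCCCN2)sc1CO`: > 110000 nM

In an ADME assay on MT2 cells (Homo sapiens) for cytotoxicity, read by XTT assay, with a stated time of 4 days (on this read-out lower numbers stand for higher toxicity in this test and higher numbers for lower toxicity in this test), compound 2 gives > 110000 nM, which is a limit of the assay and not a number. Compound 1 gives > 87000 nM, which is likewise only a limit. Compound 3 `Cc1nc(C(NC(=O)C(=O)Nc2ccc(C(F)(F)F)cc2)C2CCCCN2)sc1CO` differs from compound 2 in one place: 4-(trifluoromethyl)phenyl in place of 2,4-difluorophenyl on an amide-type nitrogen. In words, 4-(trifluoromethyl)phenyl stands in place of 2,4-difluorophenyl on an amide-type nitrogen. Among the compounds with values here, only one measured step bears on this change, and it also concerns the group on that nitrogen: a step that the two limits leave unreadable from compound 1 to compound 2. It offers no size to carry over, so no step beyond the usual scatter is expected in this assay, and no direction is expected either. The expected change is an at least 1.1-fold lower number from compound 2 to compound 3 (0.04 log units; that floor lies within the scatter). For compound 3 the estimated value is 100000 nM, with an expected range of 45000 nM to 220000 nM.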

Compound 3, half-maximal cytotoxic concentration: > 75500 nM
Compound 3 was reported as a limit (the forecaster's own chance of this, stated with the estimate: 75%); the middle value is on the limit's open side.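

Compound 3, like compound 1 and compound 2, is reported in this assay only as a limit of the assay, so no new step among these three compounds can be read. The compounds shown leave open at what concentration each becomes toxic to these cells.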